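Swapping Dimethylamino for Acetyl on a Shared Core

The source may hold more compounds than are shown below. What is called first, only, known or untested is meant among the compounds shown, and "the series" means these compounds.

Of the compounds shown here, two have been measured so far in a functional assay on HCT-15 cells (Homo sapiens) for cytotoxicity, read by sulforhodamine B assay, with a stated time of 48 h, tested at 100 nM; on this read-out higher numbers stand for a weaker effect at the one concentration tested and lower numbers for a stronger effect. Compound 1 `COc1cc(C)cc(-c2c(-c3ccnc(-c4ccc(N(C)C)cc4)c3)cnn2CC#N)c1` and compound 2 `COc1cc(C)cc(-c2nn(CC#N)cc2-c2ccnc(-c3ccc(N(C)C)cc3)c2)c1` carry the same core and the same two aromatic substituents, arranged differently around that core. In this assay compound 1 gives 14%, and compound 2 gives 15%; the two numbers lie within the usual scatter of each other, so neither can be called the stronger. Compound 1 simply holds the lower of the two numbers, which on this read-out points toward the stronger effect at the single concentration tested, by a margin that repeated measurement would blur.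

Compound 3 `COc1cc(C)cc(-c2c(-c3ccnc(-c4ccc(C(C)=O)cc4)c3)cnn2CC#N)c1` is derived from compound 1 by one change: acetyl in place of dimethylamino on an aromatic carbon. Going by the values given here, no measured pair shows what this exchange does here, so the expectation rests on the structural change alone. The step of a number 11 percentage points higher from compound 1 to compound 3 (beyond the scatter) is expected to be small, pointing, if anywhere, toward a somewhat weaker effect. Compound 3 is therefore estimated at 25%, within a range from 8% to 60%.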

Compound 3, a percentage reported as activity, at one concentration (the size of the read-out at that concentration, not a potency): 87%
The estimate for compound 3 lay 62 percentage points below the measured number; measured number above the stated range.
By their numbers in this assay, from the lowest: compounds 1 and 2 (each within the scatter of the next); then compound 3.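

The aromatic carbon para to a large group turns out to matter a great deal: in this assay, putting acetyl in place of dimethylamino gives a number 73 percentage points higher from compound 1 to compound 3 (beyond the scatter), a large step toward a weaker effect at the one concentration tested. The earlier pair differed only in how the same groups were arranged around the shared core, so it gave no view of what a change at this position can do. The two groups match in their counts of heavy atoms and hydrogen-bond acceptors, and neither carries a net charge, so those counts do not separate them, and no measurement at hand explains the step.

A single pair cannot tell whether dimethylamino favours the effect, acetyl works against it, or both, and a primary amine, diethylamino or a carboxylic acid at the same carbon would help to separate these possibilities. Going by these compounds, it also remains open whether the same exchange would move the number as far in the arrangement of compound 2.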